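The source may hold more compounds than are shown below. What is called first, only, known or untested is meant among the compounds shown, and "the series" means these compounds.

Of the compounds shown here, two have so far been measured in an assay on RPMI-8226 cells for antagonist activity at P2X purinoceptor 7 (Homo sapiens), read by calcium flux; on this read-out higher numbers stand for weaker inhibition and lower numbers for stronger inhibition. Compound 1, `O=c1[nH]c2ccccc2n1CCCN1CCC(C(O)(c2ccccc2)c2ccccc2)CC1`, gives 7500 nM in this assay. Compound 2, `Cc1cccc2c1ccn2CCCCN1CCN(C(c2ccccc2)c2ccccc2)CC1`, gives 5300 nM in this assay. Going by the values given here, the numbers of compound 2 and compound 1 lie within the usual scatter of each other, so on what is known the two cannot be told apart, and no pair of measured compounds differing in a single place is available to show the size of any one change.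

Compound 3, `Fc1ccc2ccn(CCCCN3CCN(C(c4ccccc4)c4ccccc4)CC3)c2c1`, has not yet been measured. It differs from compound 2 in one place: a group of 10 heavy atoms (8 carbon, 1 nitrogen, 1 fluorine; one five-membered aromatic ring with 1 hetero atom, one six-membered aromatic ring of carbon only) in place of a group of 10 heavy atoms (9 carbon, 1 nitrogen; one five-membered aromatic ring with 1 hetero atom, one six-membered aromatic ring of carbon only), on a saturated chain carbon, four bonds along the chain from an amine nitrogen in a ring. Among the compounds with values here, the group that leaves and the group that enters match in the count of heavy atoms and in ring makeup, and no measured pair shows what this kind of exchange does in this assay, so there is no direct guide to the size of the step.

The expected step is a 1.1-fold lower number from compound 2 to compound 3 (0.03 log units; within the scatter), which is judged not to go beyond the scatter. Compound 3 is therefore expected to give about 5000 nM in this assay, with a range from 2000 nM to 15000 nM.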

Compound 3, half-maximal inhibitory concentration: 110 nM
The estimate for compound 3 lay 45-fold (1.66 log units) above the measured number; measured number outside the range, below it.
By their numbers in this assay, from the lowest: compound 3; then compounds 2 and 1 (each within the scatter of the next).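

In this assay, exchanging the group of compound 2 for 6-fluoro-1H-indol-1-yl, on a saturated chain carbon, four bonds along the chain from an amine nitrogen in a ring, gives a 48-fold lower number from compound 2 to compound 3 (1.68 log units; beyond the scatter), the first size of a single change seen in this series. The place therefore responds strongly to a small exchange: the heavy-atom count, the ring makeup and the counts of hydrogen-bond donors and acceptors all stay the same, and only one carbon gives way to one fluorine in the atom count, so those counts alone do not predict the outcome here. Nothing measured on these compounds explains why so small an exchange has so large an effect.

As far as these compounds go, this single step cannot separate the gain of the fluorine from the loss of the extra carbon, so the share of each in the change remains unknown. From the compounds shown here alone, whether the effect is particular to fluorine also stays open, and the plain 1H-indol-1-yl group, or the same group bearing chlorine or a nitrile in place of the fluorine, would bear on both questions.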